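The source may report more compounds than this note shows. Statements on the series, on what has been measured and on what is new or still open speak of the compounds shown alone.

Measured in a functional assay on HT-29 cells (Homo sapiens) for inhibition, with a stated time of 72 h; a higher number here means a weaker inhibitor, a lower number a stronger inhibitor:
Compound 1 `COc1ccc(S(=O)(=O)N2CCc3cccc(-c4cc(OC)c(OC)c(OC)c4)c32)cc1`: 5100 nM
Compound 2 `COc1ccc(-c2cccc3c2N(S(=O)(=O)c2ccc(OC)cc2)CC3)cc1`: 277 nM
Compound 3 `COc1ccc(S(=O)(=O)N2CCc3cccc(-c4c(F)c(F)c(F)c(F)c4F)c32)cc1`: 3900 nM

Compound 2 stands lowest of the three in this assay, and compound 3 and compound 1 both lie higher, beyond the scatter. Compound 4 `COc1ccc(S(=O)(=O)N2CCc3cccc(-c4cccs4)c32)cc1` carries thiophen-2-yl in place of 4-methoxyphenyl on an aromatic carbon. Going by the values given here, no measured pair of compounds differs in one place only, so the data show no direct precedent for this change. The expectation rests on the three values alone: only compound 2 at 277 nM is low, while compound 3 at 3900 nM and compound 1 at 5100 nM are not. A move towards a weaker inhibitor is therefore expected, with an estimated 5.4-fold higher number from compound 2 to compound 4 (0.73 log units; beyond the scatter). The estimate for compound 4 is 1500 nM, within a range of 450 nM to 5000 nM.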

Compound 4, half-maximal inhibitory concentration: 200 nM
For compound 4 the middle estimate is 7.5-fold (0.88 log units) above the measured one; the whole stated range lies above it.
By their numbers in this assay, from the lowest: compounds 4 and 2 (each within the scatter of the next); then compounds 3 and 1 (each within the scatter of the next).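

In this assay, thiophen-2-yl in place of 4-methoxyphenyl on this aromatic carbon gives a 1.4-fold lower number from compound 2 to compound 4 (0.14 log units; within the scatter), so the two groups cannot be told apart here. A low number at this position therefore does not depend on a six-membered aromatic ring of carbon only, since a five-membered aromatic ring with a sulfur atom serves as well. Nothing available explains why the two groups read alike. The compounds shown leave open whether thiophen-3-yl, pyridin-3-yl or a simple amine on this carbon would keep the number low.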